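Inhibition on lung cancer cells across a small aryl series

The source may report more compounds than this note shows. Statements on the series, on what has been measured and on what is new or still open speak of the compounds shown alone.

Measured so far:
compound 1 `c1ccc2c(-c3cn4ccnc4c(-c4ccc5ncn(C6CCCCC6)c5c4)n3)cccc2c1` — 19.3%
compound 2 `Cc1cccc(-c2cn3ccnc3c(-c3ccc4ncn(Cc5ccccc5)c4c3)n2)c1` — 28.4%

Two compounds carry numbers in a functional assay on NCI-H522 cells (Homo sapiens) for inhibition, read by sulforhodamine B assay, with a stated time of 48 h, tested at 10 uM; a lower number here means less inhibition, a higher number more inhibition at the concentration tested (going by the name of the read-out). Compound 1, with a cyclohexyl group and a naphthalen-1-yl group on the shared core, gives 19.3% in this assay. Compound 2, with a benzyl group and a 3-methylphenyl group on the same core, gives 28.4%. Within the data shown here, compound 2 sits alongside compound 1 on these numbers; the gap between the two is within the usual scatter, so no order between them can be read from this pair, and no step between measured compounds is available.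

The next compound is compound 3 `c1ccc(Cn2cnc3ccc(-c4nc(-c5cccc6ccccc56)cn5ccnc45)cc32)cc1`. It keeps the benzyl group of compound 2 and takes the aryl group seen in compound 1: naphthalen-1-yl in place of 3-methylphenyl on an aromatic carbon. Since both measured compounds sit at a low level of inhibition and their gap is within scatter, the step from compound 2 to compound 3 is expected to be small or absent beyond the scatter, with a slight downward lean given the number of compound 1 19.3%; the expected step is a number 5.4 percentage points lower from compound 2 to compound 3 (within the scatter). Compound 3 is therefore estimated at 23%, within a range of 9% to 38%.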

Compound 3, a percentage reported as inhibition, at one concentration (the size of the read-out at that concentration, not a potency): 29.3%
Estimate against measurement, compound 3: 6.3 percentage points below; low and high end bracket the measured number.
By their numbers in this assay, from the lowest: compounds 1, 2 and 3 (each within the scatter of the next).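

Among these compounds, compound 3 supplies the first comparisons in which only one place differs, and neither place separates the compounds in this assay. On the aromatic carbon of the shared core, naphthalen-1-yl in place of 3-methylphenyl, with benzyl held on the aromatic nitrogen, gives a number 0.9 percentage points higher from compound 2 to compound 3 (within the scatter) and so shows that the second carbon-only aromatic ring brings no change that can be read from this step. On the aromatic nitrogen, benzyl in place of cyclohexyl, with naphthalen-1-yl held, gives a number 10 percentage points higher from compound 1 to compound 3 (within the scatter) and likewise sets no order between these two groups, while nothing measured on these compounds bears on either step.

Still open, as far as these compounds go, is whether a group of another kind on the aromatic carbon, such as a phenyl ring carrying an amine or a carboxylic acid, would move the inhibition beyond the scatter in this assay. Also open, from the compounds shown here alone, is whether a longer chain on the aromatic nitrogen, such as phenethyl in place of benzyl, would do so, and whether the two places act independently when both change together.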